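This account rests on a few compounds, and the source may have more. Where it says the series, first, only, none or still open, it means among the compounds named here.

Compound 1 `Cc1cc(C)nc(Oc2ccc(NC(=O)Nc3ccc(F)cc3)cc2)n1` is one of three compounds that share a urea linking two outer rings to a central core. In a functional assay on CNE-2 cells (Homo sapiens) for cytotoxicity, read by MTT assay, with a stated time of 3 days (on this read-out lower numbers stand for stronger inhibition and higher numbers for weaker inhibition), compound 1 gives 46900 nM. Compound 2 `Cc1cc(C)nc(Oc2ccc(NC(=O)Nc3ccc(Cl)cc3)cc2)n1` differs from it only by one change, (chloro in place of fluoro on an aromatic carbon), and in this assay compound 2 gives 20400 nM. This single swap produced a 2.3-fold lower number from compound 1 to compound 2 (0.36 log units; beyond the scatter).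

Compound 3 `Cc1cc(C)nc(Sc2ccc(NC(=O)Nc3ccc(F)cc3)cc2)n1` carries a different core from compound 1; the difference between the two cores is not broken down here. In this assay compound 3 gives 34100 nM, and the numbers for compound 3 and compound 1 lie within the usual scatter of each other, so nothing separates them.

Compound 4 `Cc1cc(C)nc(Sc2ccc(NC(=O)Nc3ccc(Cl)cc3)cc2)n1` has not yet been measured in this assay. It stands to compound 3 as compound 2 stands to compound 1: the change is chloro in place of fluoro on an aromatic carbon, at the same place in the same kind of ring. The same change is therefore expected to give a step of similar size, and the expectation of a 2.1-fold lower number from compound 3 to compound 4 (0.33 log units; beyond the scatter) rests on a 2.3-fold lower number from compound 1 to compound 2 (0.36 log units; beyond the scatter). On that basis compound 4 is estimated to give 16000 nM, expected to fall between 7000 nM and 35000 nM.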

Compound 4, half-maximal inhibitory concentration: 13500 nM
Estimate against measurement, compound 4: 1.2-fold (0.07 log units) above; measured number inside the range.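

Putting chloro in place of fluoro on the outer ring of compound 3 gives, in this assay, a 2.5-fold lower number from compound 3 to compound 4 (0.40 log units; beyond the scatter), and this step matches the one seen on the other core: the same change on two cores in this assay, a 2.3-fold lower number (0.36 log units; beyond the scatter) from compound 1 to compound 2 and a 2.5-fold lower number (0.40 log units; beyond the scatter) from compound 3 to compound 4, 1.1-fold (0.04 log units) apart, within the scatter of two such steps

Within these four compounds, then, the change carries from one core to the other with its direction and size kept. For the compounds shown here, this rests on only two pairs and two cores in a single cell assay, so it does not show that the step would hold on any further core, and it does not explain why chloro gives the lower number.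

The compounds shown leave open what other groups would do at that same place on the ring, such as bromo, methyl or methoxy. They also leave open whether the step would survive if the urea gave way to an amide, or if an amine took the place of the methyl groups on the core.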